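Bulkier Group on the Ring Nitrogen of Compound 1

A few compounds are considered here, and "the series" means these few. Any claim that something is new, unique, unknown or untested is made for them only; others in the source may bear on it.

Compound 1 `COc1ccc(-c2cc(=O)c3c(OC)cc(OC)cc3n2C)cc1` carries a methyl on its ring nitrogen. In a functional assay on SUP-B15 cells (Homo sapiens) for antiproliferative activity, with a stated time of 72 h (a higher number here means that more compound is needed for the effect, a lower number that less compound is needed), compound 1 gives 28000 nM, the highest of the two numbers; compound 2 `COC(=O)c1cc(=O)c2c(OC)cc(OC)cc2[nH]1` gives 16100 nM, and that gap is within the scatter. Compound 3 `COC(=O)c1cc(=O)c2c(OC)cc(OC)cc2n1C` reaches only the limit > 37900 nM. Compound 4 `COc1ccc(-c2cc(=O)c3c(OC)cc(OC)cc3n2S(=O)(=O)c2ccc(C=O)cc2)cc1` differs from compound 1 by (4-formylphenyl)sulfonyl in place of methyl on an aromatic nitrogen. Within the data shown here, two measured steps bear on this: an at least 2.3-fold higher number from compound 2 to compound 3 (0.37 log units; beyond the scatter), also on the ring nitrogen, and an at least 1.3-fold higher number from compound 1 to compound 3 (0.13 log units; that floor lies within the scatter), on a ring carbon. One value behind those steps is a limit (the limit of > 37900 nM in this assay, at which 1 of the 3 values shown sits). Adding a group to the nitrogen thus raised the number, and a far larger group is expected to do the same or more. Compound 4 is therefore expected at 35000 nM, between 9000 nM and 90000 nM, a step of a 1.3-fold higher number from compound 1 to compound 4 (0.10 log units; within the scatter).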

Compound 4, half-maximal effective concentration: > 34400 nM
Compound 4: only a limit was reported (the forecaster's own chance of this, stated with the estimate: 35%); the middle value does not contradict the limit.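

Within this assay the swap of methyl for (4-formylphenyl)sulfonyl on the ring nitrogen gives an at least 1.2-fold higher number from compound 1 to compound 4 (0.08 log units; that floor lies within the scatter) and so no sign of a lower number. Among these compounds, until now this nitrogen carried only hydrogen or methyl, so this is the first look at a much larger group with its own aromatic ring there. The reading for compound 4 is a limit and not a number: the limit of > 34400 nM in this assay, at which 1 of the 4 values shown sits.

On these data alone, whether a short chain such as ethyl, or a benzyl group, on this nitrogen would give a readable number stays open. So does the effect of plain hydrogen there with the 4-methoxyphenyl group kept.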